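The compounds below may be only part of what the source reports. "The series", "measured", "known", "first", "only" and "open" are said of these compounds alone.

Of the compounds shown here, three that share one core have been tested in an ADME assay on MT4 cells (Homo sapiens) for cytotoxicity, read by MTT assay, with a stated time of 3 days; on this read-out higher numbers stand for lower toxicity in this test and lower numbers for higher toxicity in this test. Compound 1 `CC(C)(C)N(CCCc1ccccc1)C(=O)COC(=O)c1ccc([N+](=O)[O-])o1` gives "not active" (no number reported), with no number reported. Compound 2 `CC(=O)Oc1ccc(CN(C(=O)COC(=O)c2ccc([N+](=O)[O-])o2)C(C)(C)C)cc1` gives > 100000 nM, which is a limit of the assay and not a number. Among the measured compounds shown here, compound 3 `CC(C)(C)N(Cc1ccc(C(F)(F)F)cc1)C(=O)COC(=O)c1ccc([N+](=O)[O-])o1` gives 71000 nM, the only actual number among the three, so its standing rests on little.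

Compound 4 `CC(C)(C)N(Cc1cccc(C(F)(F)F)c1)C(=O)COC(=O)c1ccc([N+](=O)[O-])o1` has yet to be measured. It has the same atoms as compound 3, joined differently: 3-(trifluoromethyl)phenyl in place of 4-(trifluoromethyl)phenyl on a saturated chain carbon bound to an amide-type nitrogen, with 3-(trifluoromethyl)phenyl in place of 4-(trifluoromethyl)phenyl on a saturated chain carbon bound to an amide-type nitrogen.

For the measured compounds named here, only one measured step offers any guide, and a weak one: an at least 1.4-fold lower number from compound 2 to compound 3 (0.14 log units; that floor lies within the scatter), which stays within the scatter. Going by the values given here, that step puts trifluoromethyl in place of acetoxy on an aromatic carbon, and no measured step shows what moving the trifluoromethyl group does. No change beyond the scatter is therefore expected, and the estimated step is a 1.0-fold lower number from compound 3 to compound 4 (0.01 log units; within the scatter). For compound 4 the expected value is 70000 nM, with an estimated range from 35000 nM to 100000 nM.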

Compound 4, half-maximal cytotoxic concentration: > 100000 nM
Compound 4 was reported as a limit; the forecaster's own chance of this, stated with the estimate: 35%; middle value at least 1.4-fold (0.15 log units) from the limit.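

Among the compounds shown here, replacing 4-(trifluoromethyl)phenyl with 3-(trifluoromethyl)phenyl on a saturated chain carbon bound to an amide-type nitrogen is the first measured change here that keeps the same atoms, and in this assay it gives an at least 1.4-fold higher number from compound 3 to compound 4 (0.14 log units; that floor lies within the scatter). Compound 4 gives a limit of the assay and not a number, so this step provides only a floor, and that floor does not show a real difference between the two isomers. The step linking compound 2 and compound 4 cannot be read, and the upper end of the assay now restricts what these compounds can reveal: the limit of > 100000 nM in this assay, at which 2 of the 4 values shown sit.

Going by these compounds, whether moving the trifluoromethyl group changes toxicity in this test at all remains open. Also open, on these data alone, is how the number would respond if a nitrile, an amine or a carboxylic acid replaced trifluoromethyl on the aromatic ring.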